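The compounds below may be only part of what the source reports. "The series", "measured", "known", "first", "only" and "open" are said of these compounds alone.

Measured compounds:
- compound 1 `COc1cc(/C=C/C(=O)c2cccc(NC(=O)c3c(Cl)cccc3Cl)c2)ccc1O`: in a functional assay on HUVEC cells (Homo sapiens) for inhibition, tested at 10 ug/mL (a lower number here means a weaker effect, a higher number a stronger effect of the compound at the concentration tested), compound 1 gives 99%
- compound 2 `COc1cc(/C=C/C(=O)c2cccc(NC(=O)c3ccc(Cl)cc3Cl)c2)ccc1O`: in this assay compound 2 gives 70%

For the measured compounds named here, compound 2 stands lowest of the two numbers; its nearest neighbour is compound 1, and the only measured step is a number 29 percentage points lower from compound 1 to compound 2 (beyond the scatter). Compound 3 `COc1cc(/C=C/C(=O)c2cccc(NC(=O)c3ccc(Cl)c(Cl)c3)c2)ccc1O` arises from compound 2 by 3,4-dichlorophenyl in place of 2,4-dichlorophenyl on a carbonyl carbon. Going by the values given here, the one step that bears on this is the step from compound 1 to compound 2, a modest one beyond the scatter, which shows that rearranging the two chlorines on that ring can move the read-out by that much, though it says nothing about the direction for 3,4-dichlorophenyl. A step of similar size in either direction, or none beyond the scatter, is therefore expected, written as a number 2 percentage points higher from compound 2 to compound 3 (within the scatter). For compound 3 the estimate is 72%, between 40% and 97%.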

Compound 3, a percentage reported as inhibition, at one concentration (the size of the read-out at that concentration, not a potency): 45%
The estimate for compound 3 lay 27 percentage points above the measured number; measured number inside the range.
By their numbers in this assay, from the lowest: compound 3; then compound 2; then compound 1.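

In this assay, moving to 3,4-dichlorophenyl on the carbonyl carbon gives a number 25 percentage points lower from compound 2 to compound 3 (beyond the scatter), while the change from 2,6-dichlorophenyl gives a number 54 percentage points lower from compound 1 to compound 3 (beyond the scatter). The direction left unknown by the earlier pair is now settled for this change, and the three dichlorophenyl groups, which have the same atoms, give three read-outs that all lie beyond the scatter of one another, with compound 1 the strongest and compound 3 the weakest. Rearranging the chlorines alone can therefore shift the read-out at this position by a large amount, although nothing available explains this order.

The compounds shown leave open how an unsubstituted phenyl or a phenyl with a single chlorine would compare. They also leave open whether the same order would hold with two fluorines or two methoxy groups in place of the chlorines.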